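This account rests on a few compounds, and the source may have more. Where it says the series, first, only, none or still open, it means among the compounds named here.

Compound 1 `CNc1c(-c2ccc(=O)n(-c3ccccc3C)n2)c(-c2ccc(F)cc2)nn1C`: 20.6 mL/min/kg
Compound 2 `Cc1ccccc1-n1nc(-c2c(-c3ccc(F)cc3)nn3c2NC[C@@H](O)C3)ccc1=O`: 4.8 mL/min/kg

Going by the values given here, in an in vivo ADME assay on the whole organism (strain Sprague-Dawley) for pharmacokinetics, with Rattus norvegicus as the target, at a dose of 1 mg/kg by the intravenous route (on this read-out lower numbers stand for slow clearance and higher numbers for fast clearance), compound 2 gives 4.8 mL/min/kg, the lower of the two numbers so far. Compound 1 gives 20.6 mL/min/kg, and this gap lies beyond the usual scatter. The two compounds differ in more than one place, so their gap says little about any single change.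

Compound 3 `Cc1ccccc1-n1nc(-c2c(-c3ccc(F)cc3)nn3c2NC[C@H](O)C3)ccc1=O` is built from the same atoms and bonds as compound 2, and only its spatial arrangement differs: the two compounds have the same atoms and bonds and differ only in configuration as drawn: 1 of 1 stereo elements differ; a stereocentre at a saturated ring carbon is drawn R in compound 2 and S in compound 3. Among the compounds with values here, no measured pair here shows what such a swap does to clearance, so any expectation is loose. With compound 2 at 4.8 mL/min/kg, the lowest number yet, a small rise seems likelier than a fall. The expected 1.4-fold higher number from compound 2 to compound 3 (0.13 log units; within the scatter) is modest and probably within the scatter. For compound 3 the estimate is 6.5 mL/min/kg, with an expected range from 2.8 mL/min/kg to 15 mL/min/kg.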

Compound 3, clearance: 9.53 mL/min/kg
Compound 3: the middle estimate sits 1.5-fold (0.17 log units) below what was measured, within the range that was stated.
By their numbers in this assay, from the lowest: compounds 2 and 3 (each within the scatter of the next); then compound 1.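

Going by these compounds alone, this is the first pair here that can be read as a single change, because nothing else separates the two: the fact that compounds 2 and 3 differ only in the configuration as drawn. In this assay, turning the stereocentre at the saturated ring carbon from R to S gives a 2.0-fold higher number from compound 2 to compound 3 (0.30 log units; within the scatter), so at this position the drawn configuration shows no difference in clearance that stands clear of the usual scatter. That reading holds only for this one stereocentre, with the rest of the molecule kept the same.

The compounds shown leave open whether clearance responds to the group on that ring carbon rather than to its orientation, which an amine or a methoxy group there, in each configuration, could test. Repeated measurements would also be needed to tell whether this pair truly differs at all.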